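A few compounds are considered here, and "the series" means these few. Any claim that something is new, unique, unknown or untested is made for them only; others in the source may bear on it.

Working notes on the series, read in a functional assay on PC-3 cells (Homo sapiens) for cytotoxicity, read by MTT assay, with a stated time of 72 h; a lower number here means a stronger inhibitor, a higher number a weaker inhibitor. Compound 1 (`O=C(N/N=C/c1ccc(F)cc1Cl)Nc1cc2c(Nc3ccc(F)c(Cl)c3)ncnc2cc1O[C@H]1CCOC1`) gives 28400 nM, and compound 2 (`COc1ccc(/C=N/NC(=O)Nc2cc3c(Nc4ccc(F)c(Cl)c4)ncnc3cc2O[C@H]2CCOC2)cc1`) gives 34100 nM. These two numbers lie within the scatter of each other, so compound 2 stands level with compound 1 and the series has no resolved order so far.

The next structure is compound 3 (`COc1cc(/C=N/NC(=O)Nc2cc3c(Nc4ccc(F)c(Cl)c4)ncnc3cc2O[C@H]2CCOC2)cc(OC)c1OC`), which carries 3,4,5-trimethoxyphenyl in place of 4-methoxyphenyl on a carbon with a double bond to nitrogen.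

Within the data shown here, one measured step bears on this change: a 1.2-fold higher number from compound 1 to compound 2 (0.08 log units; within the scatter). It is an exchange of the group at the same place, and it stays within the scatter. Among the measured compounds shown here, no measured step shows what 3,4,5-trimethoxyphenyl itself does, so this single precedent gives only weak support and the range is kept wide.

No step beyond the scatter is expected in this assay, and no direction is favoured. The expected step is a 1.1-fold lower number from compound 2 to compound 3 (0.04 log units; within the scatter). In this assay, the estimated value for compound 3 is 31000 nM, with an expected range of 13000 nM to 70000 nM.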

Compound 3, half-maximal inhibitory concentration: 29600 nM
Compound 3: the middle estimate sits 1.0-fold (0.02 log units) above what was measured; measured number inside the range.
By their numbers in this assay, from the lowest: compounds 1, 3 and 2 (each within the scatter of the next).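

In this assay, 3,4,5-trimethoxyphenyl in place of 4-methoxyphenyl on a carbon with a double bond to nitrogen gives a 1.2-fold lower number from compound 2 to compound 3 (0.06 log units; within the scatter) and 3,4,5-trimethoxyphenyl in place of 2-chloro-4-fluorophenyl at the same place gives a 1.0-fold higher number from compound 1 to compound 3 (0.02 log units; within the scatter). Among these compounds, the earlier pair showed only one exchange between a halogen-bearing and a methoxy-bearing phenyl; this result adds that going from 8 heavy atoms to 12 heavy atoms, and from 1 hydrogen-bond acceptor to 3 hydrogen-bond acceptors, also stays within the scatter, so compound 1, compound 2 and compound 3 have no resolved order. No measurement available here accounts for this lack of separation.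

From the compounds shown here alone, all three compounds carry a six-membered aromatic ring of carbon only at this place, so it remains open whether a group without such a ring, such as an amine, a carboxylic acid or a longer alkyl chain, would move the number beyond the scatter. The compounds shown also share the rest of the structure, which leaves open whether a change elsewhere on the shared core would move the number in this assay.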